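A Methyl-for-Chloro Swap Ahead of Its Measurement

The compounds below may be only part of what the source reports. "The series", "measured", "known", "first", "only" and "open" are said of these compounds alone.

Compound 1 `C=CCN(Cc1ccc2nc(C)[nH]c(=O)c2c1)c1ccc(C(=O)N[C@@H](CCC(=O)O)C(=O)O)cc1F`: 5160 nM
Compound 2 `CCN(Cc1ccc2nc(C)[nH]c(=O)c2c1)c1ccc(C(=O)N[C@@H](CCC(=O)O)C(=O)O)c(C)c1`: 320 nM
Compound 3 `Cc1nc2ccc(CNc3ccc(C(=O)N[C@@H](CCC(=O)O)C(=O)O)cc3F)cc2c(=O)[nH]1`: 9340 nM

In an assay on isolated protein for inhibition of Thymidylate synthase (Mus musculus) (on this read-out higher numbers stand for weaker inhibition and lower numbers for stronger inhibition), compound 2 gives the lowest number of the three, with compound 1 higher and compound 3 higher still, both clearly beyond the scatter. For the measured compounds named here, the one measured single-point step, a 1.8-fold higher number from compound 1 to compound 3 (0.26 log units; within the scatter), concerns hydrogen in place of allyl on a nitrogen on an aromatic ring and leaves the shared core untouched. Compound 4 `CCN(Cc1ccc2nc(C)[nH]c(=O)c2c1)c1ccc(C(=O)N[C@@H](CCC(=O)O)C(=O)O)c(Cl)c1` differs from compound 2 by chloro in place of methyl on an aromatic carbon. Going by the values given here, no measured step bears on this change; compounds 1 and 3 differ from compound 2 in more than one place, so they do not isolate it. The step from compound 2 to compound 4 is therefore expected to be small, a 1.3-fold higher number from compound 2 to compound 4 (0.10 log units; within the scatter), with no direction established beyond the scatter. Compound 4 is estimated at 400 nM, within 130 nM to 1300 nM.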

Compound 4, half-maximal inhibitory concentration: 120 nM
Beside the measured number, compound 4's estimate is 3.3-fold (0.52 log units) above it, and the stated range ends above it.
By their numbers in this assay, from the lowest: compound 4; then compound 2; then compounds 1 and 3 (each within the scatter of the next).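

In this assay, chloro in place of methyl on an aromatic carbon gives a 2.7-fold lower number from compound 2 to compound 4 (0.43 log units; beyond the scatter) and so makes a modest step that lies beyond the scatter. The earlier compounds shown here held no step at this position, ortho to a large group and meta to a large group, and this one shows that the number responds to the group there with the rest of the molecule unchanged. Nothing available accounts for the step.

On these data alone, whether bromo or methoxy at this position would go further stays open. So does whether the swap holds with allyl on the nitrogen.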